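This account rests on a few compounds, and the source may have more. Where it says the series, first, only, none or still open, it means among the compounds named here.

Compound 1 `COc1nc(OC)nc(N2CCC(c3nc(C(=O)N4CCN(c5cccc(C(F)(F)F)c5)CC4)cs3)CC2)n1`: 15000 nM
Compound 2 `O=C(c1ccccc1)c1ccc2[nH]c(NC(=O)c3csc(C4CCN(c5ccnc6ncnn56)CC4)n3)nc2c1`: 3600 nM

In a functional assay on PBMC cells (Homo sapiens) for antiproliferative activity (on this read-out higher numbers stand for weaker inhibition and lower numbers for stronger inhibition), compound 2 stands at the lower of the two numbers; compound 1 sits beyond the scatter above it. Compound 3 `O=C(c1ccccc1)c1ccc2[nH]c(NC(=O)c3csc(C4CCN(c5ncnc6ccsc56)CC4)n3)nc2c1` differs from compound 2 by a group of 9 heavy atoms (6 carbon, 2 nitrogen, 1 sulfur; one five-membered aromatic ring with 1 hetero atom, one six-membered aromatic ring with 2 hetero atoms) in place of a group of 9 heavy atoms (5 carbon, 4 nitrogen; one five-membered aromatic ring with 3 hetero atoms, one six-membered aromatic ring with 2 hetero atoms), on an amine nitrogen in a ring. Going by the values given here, no measured pair shows a change of this kind, so no step size can be read off. The step of a 1.0-fold lower number from compound 2 to compound 3 (0.01 log units; within the scatter) is expected to stay within the scatter, in no settled direction. Compound 3 is therefore estimated at 3500 nM in this assay, with a range from 900 nM to 14000 nM.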

Compound 3, half-maximal inhibitory concentration: 2200 nM
Estimate against measurement, compound 3: 1.6-fold (0.20 log units) above; measured number inside the range.
By their numbers in this assay, from the lowest: compounds 3 and 2 (each within the scatter of the next); then compound 1.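

In this assay, going by these compounds alone, the first comparison at the amine nitrogen in a ring comes with a 1.6-fold lower number from compound 2 to compound 3 (0.21 log units; within the scatter). Replacing the group with a five-membered aromatic ring with 3 hetero atoms by one with a five-membered aromatic ring with 1 hetero atom, sulfur among its atoms, therefore leaves the number within the scatter. No measured data on this result offer an explanation for it. The compounds shown leave open whether a single phenyl ring or a small alkyl chain such as methyl on this nitrogen would move the number beyond the scatter.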